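This account rests on a few compounds, and the source may have more. Where it says the series, first, only, none or still open, it means among the compounds named here.

Compound 1 `COc1cc(-c2ccnc3cc(-c4ccc(Cl)cc4)nn23)cc(OC)c1OC` gives 3340 nM in a functional assay on HCT-116 cells (Homo sapiens) for inhibition, read by CCK-8 assay, with a stated time of 48 h (on this read-out higher numbers stand for weaker inhibition and lower numbers for stronger inhibition), the highest of the three numbers in hand. Compound 2 `COc1cc(-c2ccnc3cc(-c4ccc(C)cc4)nn23)cc(OC)c1OC` gives 48 nM in this assay, and compound 3 `COc1ccc(-c2cc3nccc(-c4cc(OC)c(OC)c(OC)c4)n3n2)cc1N` gives 251 nM. Compound 4 `COc1cc(-c2ccnc3cc(-c4ccc(C(C)(C)C)cc4)nn23)cc(OC)c1OC` is not yet measured; it differs from compound 1 in one place: tert-butyl in place of chloro on an aromatic carbon. The measured step bearing most directly on this change is a 70-fold lower number from compound 1 to compound 2 (1.84 log units; beyond the scatter), an alkyl group in place of the same chloro at the same aromatic carbon. The other steps point the same way from compound 1: a 13-fold lower number from compound 1 to compound 3 (1.12 log units; beyond the scatter), while a 5.2-fold higher number from compound 2 to compound 3 (0.72 log units; beyond the scatter) leaves compound 2 with the lowest number of the three. A lower number than that of compound 1 is therefore expected for compound 4 in this assay. Among the measured compounds shown here, no measured pair covers methyl against tert-butyl, so the expected step of a 17-fold lower number from compound 1 to compound 4 (1.22 log units; beyond the scatter) is set smaller than the step to compound 2 and given a wide range. Compound 4 is estimated at 200 nM, between 40 nM and 1500 nM.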

Compound 4, half-maximal inhibitory concentration: > 10000 nM
Compound 4 gave a limit, no number; the forecaster's own chance of this, stated with the estimate: 3%; middle value at least 50-fold (1.69 log units) away from the limit.
By their numbers in this assay, from the lowest: compound 2; then compound 3; then compound 1. At a limit, above all of these: compound 4.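

In this assay compound 4 gives > 10000 nM, which is a limit of the assay and not a number. An alkyl group in place of chloro is therefore no general gain at this aromatic carbon: tert-butyl gives an at least 2.9-fold higher number from compound 1 to compound 4 (0.47 log units; beyond the scatter), against the direction of the methyl step, and tert-butyl in place of methyl gives an at least 200-fold higher number from compound 2 to compound 4 (2.31 log units; beyond the scatter). The choice of aryl group at this place carries a large difference in this series, with an at least 39-fold higher number from compound 3 to compound 4 (1.60 log units; beyond the scatter).

From the compounds shown here alone, how the number runs between methyl and tert-butyl remains open, and ethyl or isopropyl at the same carbon would bear on that. Also open, going by these compounds, is whether a group such as an amine or a hydroxyl alone at this carbon, para to the same large group, would keep the low numbers.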